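Chloro substitution on a fused ring of a cinnamylidene imine

A few compounds are considered here, and "the series" means these few. Any claim that something is new, unique, unknown or untested is made for them only; others in the source may bear on it.

The series rests on a shared imine-linked core. Compound 1 `Clc1ccccc1/C=N/c1sc2c(c1-c1nc3ccccc3s1)CCC2` and compound 2 `Clc1ccc(/C=N/c2sc3c(c2-c2nc4ccccc4s2)CCC3)c(Cl)c1` carry the same core, while compound 3 `C(=C/c1ccccc1)\C=N\c1sc2c(c1-c1nc3ccccc3s1)CCCC2` is built on a different one; the difference between the two cores is not broken down here. Cytotoxicity was measured in an ADME assay on HepG2 cells (Homo sapiens) for cytotoxicity, read by MTT assay, with a stated time of 72 h; on this read-out higher numbers stand for lower toxicity in this test and lower numbers for higher toxicity in this test. In this assay compound 1 gives 180 ug/mL, compound 2 gives 310 ug/mL, and compound 3 gives 467 ug/mL.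

Compound 2 differs from compound 1 by chloro in place of hydrogen on an aromatic carbon. The effect of that change is a 1.7-fold higher number from compound 1 to compound 2 (0.24 log units; within the scatter).

Compound 4 `Clc1ccc2sc(-c3c(/N=C/C=C/c4ccccc4)sc4c3CCCC4)nc2c1` has not yet been measured. It differs from compound 3 by chloro in place of hydrogen on an aromatic carbon. This is the same kind of change as that from compound 1 to compound 2, but the place is not the same: in compound 2 the chlorine enters meta to a chloro group and para to a large group on a ring of carbon only, whereas in compound 4 it enters on a ring that is part of a fused or bridged system of two rings, meta to a fused ring and para to a fused ring.

Among the measured compounds shown here, the only measured precedent is the step from compound 1 to compound 2, a 1.7-fold higher number from compound 1 to compound 2 (0.24 log units; within the scatter), which stayed within the scatter, so a similar small step is expected here: the expected step is a 1.2-fold higher number from compound 3 to compound 4 (0.07 log units; within the scatter). On that basis compound 4 is estimated at 550 ug/mL in this assay, expected to fall between 280 ug/mL and 1100 ug/mL.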

Compound 4, half-maximal cytotoxic concentration: 114 ug/mL
Estimate against measurement, compound 4: 4.8-fold (0.68 log units) above, outside the stated range (below it).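

In this assay, chloro in place of hydrogen on an aromatic carbon of the fused system gives a 4.1-fold lower number from compound 3 to compound 4 (0.61 log units; beyond the scatter), a step toward higher toxicity in this test. The same kind of change therefore does not give the same result on the two cores, and a step seen on one core cannot be carried over to the other in this series: the same change on two cores in this assay, a 1.7-fold higher number (0.24 log units; within the scatter) from compound 1 to compound 2 and a 4.1-fold lower number (0.61 log units; beyond the scatter) from compound 3 to compound 4, 7.1-fold (0.85 log units) apart, beyond the scatter of two such steps What this does not show is whether the core or the place of the chlorine decides the outcome, as the chlorine enters a ring of carbon only in compound 2 and a ring that is part of a fused system in compound 4, and two steps cannot separate those two differences or establish a rule for the series.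

The compounds shown leave open what chloro would do at the matching place on the core of compound 1, and so whether the larger step belongs to that place or to the core of compound 3. They also leave open whether a fluoro group, a methoxy group or an amine at the place taken by chlorine in compound 4 would move the number in the same way.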